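Side-chain variation at the hydroxy position: compound 4

The source may report more compounds than this note shows. Statements on the series, on what has been measured and on what is new or still open speak of the compounds shown alone.

Compound 1 `COc1ccc(C[C@H]2C(=O)N[C@@H](C)C(=O)N(C)[C@H]3Cc4ccc(cc4)Oc4cc(ccc4OC)C[C@@H](C(=O)N[C@H](C)C(=O)N[C@@H](CO)C(=O)N2C)N(C)C3=O)cc1` gives 14.1 nM in a functional assay on P388 cells (Mus musculus) for cytotoxicity (a lower number here means a stronger inhibitor, a higher number a weaker inhibitor), the lowest number among the three measured compounds. Compound 2 `COc1ccc(C[C@H]2C(=O)N[C@@H](C)C(=O)N(C)[C@H]3Cc4ccc(cc4)Oc4cc(ccc4OC)C[C@@H](C(=O)N[C@H](C)C(=O)N[C@@H](CS)C(=O)N2C)N(C)C3=O)cc1` gives 363 nM in this assay, and compound 3 `C=CC[C@@H]1NC(=O)[C@@H](C)NC(=O)[C@@H]2Cc3ccc(OC)c(c3)Oc3ccc(cc3)C[C@@H](C(=O)N2C)N(C)C(=O)[C@H](C)NC(=O)[C@H](Cc2ccc(OC)cc2)N(C)C1=O` gives 38.9 nM. The two steps away from hydroxy read a 26-fold higher number from compound 1 to compound 2 (1.41 log units; beyond the scatter) and a 2.8-fold higher number from compound 1 to compound 3 (0.44 log units; beyond the scatter); between the two replacements the step is a 9.3-fold lower number from compound 2 to compound 3 (0.97 log units; beyond the scatter). Compound 4 `COc1ccc(C[C@H]2C(=O)N[C@@H](C)C(=O)N(C)[C@H]3Cc4ccc(cc4)Oc4cc(ccc4OC)C[C@@H](C(=O)N[C@H](C)C(=O)N[C@@H](CCCN=[N+]=[N-])C(=O)N2C)N(C)C3=O)cc1` differs from compound 1 by 2-azidoethyl in place of hydroxy on a saturated chain carbon bound to a saturated ring carbon. Both measured replacements of hydroxy raised the number, so a higher number is expected for compound 4, by a 4.3-fold higher number from compound 1 to compound 4 (0.63 log units; beyond the scatter). The size is uncertain because the measured steps span a 2.8-fold higher number from compound 1 to compound 3 (0.44 log units; beyond the scatter) to a 26-fold higher number from compound 1 to compound 2 (1.41 log units; beyond the scatter). Compound 4 is estimated at 60 nM, within a range of 20 nM to 250 nM.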

Compound 4, half-maximal inhibitory concentration: 35.5 nM
The estimate for compound 4 lay 1.7-fold (0.23 log units) above the measured number, and the stated range covers the measured number.
By their numbers in this assay, from the lowest: compound 1; then compounds 4 and 3 (each within the scatter of the next); then compound 2.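

In this assay, the larger replacement 2-azidoethyl still gives only a 2.5-fold higher number from compound 1 to compound 4 (0.40 log units; beyond the scatter), so this position tolerates 3-azidopropyl in place of hydroxymethyl without a large loss. Vinyl and 2-azidoethyl cannot be told apart, at a 1.1-fold lower number from compound 3 to compound 4 (0.04 log units; within the scatter). Going by these compounds alone, with a 10-fold lower number from compound 2 to compound 4 (1.01 log units; beyond the scatter), sulfanyl stands alone among the replacements as the one with a large step from hydroxy.

Nothing available explains why sulfanyl differs from the other replacements. On these data alone, whether an amine or a carboxylic acid on a chain at this position would keep the number close to that of compound 4 remains open.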